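A few compounds are considered here, and "the series" means these few. Any claim that something is new, unique, unknown or untested is made for them only; others in the source may bear on it.

Compound 1, `Cc1ccc(NC(=O)N[C@H](C)c2ccccc2)cc1`, gives 64% in an ADME assay on the whole organism with Oryza sativa as the target, tested at 10 uM; a lower number here means a stronger effect, a higher number a weaker effect of the compound at the concentration tested.
Compound 2, `CC(C)c1ccc(NC(=O)N[C@H](C)c2ccccc2)cc1`, gives 49%.
Compound 3, `CC(C)c1ccc(NC(=O)N[C@@H](C)c2ccccc2)cc1`, gives 86%.

Among these three numbers compound 2 stands lowest. Its steps to both other compounds lie beyond the scatter, so it shows the strongest effect of the three in this assay. The nearer neighbour is compound 1, with a number 15 percentage points lower from compound 1 to compound 2 (beyond the scatter). The further neighbour is compound 3, with a number 37 percentage points higher from compound 2 to compound 3 (beyond the scatter), a step that rests on (the fact that compounds 2 and 3 differ only in the configuration as drawn).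

Compound 4, `C[C@@H](NC(=O)Nc1ccc(C(C)(C)C)cc1)c1ccccc1`, has not yet been measured in this assay. It differs from compound 2 in one place: methyl in place of hydrogen on a saturated chain carbon bound to an aromatic carbon and two saturated chain carbons. This continues the growth of the same group on the aromatic carbon that gave the modest step of a number 15 percentage points lower from compound 1 to compound 2 (beyond the scatter), and it keeps the configuration of compound 2, so the large step of a number 37 percentage points higher from compound 2 to compound 3 (beyond the scatter) does not bear on it. A further small lowering, or no change beyond the scatter, is therefore expected in this assay.

Compound 4 is estimated to give 42%, with a likely range from 25% to 62%. That estimate means an expected step of a number 7 percentage points lower from compound 2 to compound 4 (within the scatter).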

Compound 4, a percentage reported as activity, at one concentration (the size of the read-out at that concentration, not a potency): 53%
Beside the measured number, compound 4's estimate is 11 percentage points below it; measured number inside the range.
By their numbers in this assay, from the lowest: compounds 2 and 4 (each within the scatter of the next); then compound 1; then compound 3.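

In this assay the change from isopropyl to tert-butyl gives a number 4 percentage points higher from compound 2 to compound 4 (within the scatter) and so no readable difference, which means that adding this one methyl to the group on the aromatic carbon does not carry the earlier fall in the number any further. Set against the methyl group of the starting compound, the tert-butyl group gives a number 11 percentage points lower from compound 1 to compound 4 (beyond the scatter) and so keeps a real distance from it, which shows that the gain seen with isopropyl is not lost when the group grows again. Nothing measured among these compounds gives a reason for either of these two results.

The groups shown on this aromatic carbon are all made only of carbon and hydrogen, so it remains open how a methoxy group, a chlorine atom or an amine would read there. On these data alone, it is also open whether tert-butyl, drawn with the opposite configuration at the stereocentre on the chain, would repeat the step of a number 37 percentage points higher from compound 2 to compound 3 (beyond the scatter) seen with isopropyl.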